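Methoxy in Place of Hydrogen on a Fused Ring

The compounds below may be only part of what the source reports. "The series", "measured", "known", "first", "only" and "open" are said of these compounds alone.

Compound 1, `CCn1c(=O)/c(=C2\Sc3ccc(C)cc3N2C)s/c1=C\c1ccncc1Nc1ccccc1Cl`: 350 nM
Compound 2, `CCn1c(=O)/c(=C2\Sc3ccccc3N2C)s/c1=C\c1ccncc1Nc1ccccc1Cl`: 460 nM

Of the compounds shown here, two sharing one core have been tested in a functional assay on CWR22R cells (Homo sapiens) for inhibition; on this read-out higher numbers stand for weaker inhibition and lower numbers for stronger inhibition. Compound 1 gives 350 nM, and compound 2 gives 460 nM. Compound 2 stands at the higher of the two numbers, but the step of a 1.3-fold higher number from compound 1 to compound 2 (0.12 log units; within the scatter) lies within the scatter, so the two compounds are not distinguishable on this read-out.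

Compound 3, `CCn1c(=O)/c(=C2\Sc3ccc(OC)cc3N2C)s/c1=C\c1ccncc1Nc1ccccc1Cl`, has not yet been measured. It differs from compound 2 by one change: methoxy in place of hydrogen on an aromatic carbon. Going by the values given here, the one measured step that bears on this change is a 1.3-fold higher number from compound 1 to compound 2 (0.12 log units; within the scatter), in which a methyl at the same aromatic carbon was exchanged for hydrogen without a shift beyond the scatter. The methoxy group enters at that carbon. On this slender basis, compound 3 is expected to give a number close to that of compound 2, with the step of a 1.2-fold lower number from compound 2 to compound 3 (0.06 log units; within the scatter) estimated to fall within the scatter. Compound 3 is therefore estimated at 400 nM, with a range from 180 nM to 900 nM.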

Compound 3, half-maximal inhibitory concentration: 500 nM
Beside the measured number, compound 3's estimate is 1.3-fold (0.10 log units) below it; the measured number falls inside the stated range.
By their numbers in this assay, from the lowest: compounds 1, 2 and 3 (each within the scatter of the next).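

In this assay the exchange of hydrogen for methoxy on this aromatic carbon gives a small step (a 1.1-fold higher number from compound 2 to compound 3 (0.04 log units; within the scatter)), and the exchange of methyl for methoxy at the same carbon gives another (a 1.4-fold higher number from compound 1 to compound 3 (0.15 log units; within the scatter)). The earlier pair compared only hydrogen and methyl here, whereas this result adds a group of 2 heavy atoms that carries an oxygen and counts 1 hydrogen-bond acceptor, and the three compounds still cannot be told apart on this read-out. No measurement is available that would explain this outcome or link it to any property of the methoxy group.

Three groups with no separable difference between them say little about how far this carbon can be changed, so an amine, a carboxylic acid or a longer chain such as butoxy could give a very different number here. The compounds shown also leave open whether the same exchanges would give equally small steps at the other aromatic carbons of this ring.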